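Three Amides Measured, a Fourth Awaiting Its Number

This account rests on a few compounds, and the source may have more. Where it says the series, first, only, none or still open, it means among the compounds named here.

Measured so far in a functional assay on MGC-803 cells (Homo sapiens) for inhibition, read by MTT assay, with a stated time of 48 h; a lower number here means a stronger inhibitor, a higher number a weaker inhibitor:
compound 1, `COc1cc(N(Cc2nc3ccccc3[nH]2)C(=O)c2ccccc2)cc(OC)c1OC`: > 50000 nM
compound 2, `COc1cc(N(Cc2nc3ccccc3[nH]2)C(=O)c2ccc(Br)cc2)cc(OC)c1OC`: 14600 nM
compound 3, `COc1cc(N(Cc2nc3ccccc3[nH]2)C(=O)c2cccc(Cl)c2)cc(OC)c1OC`: > 50000 nM

The value of compound 3 is a limit of the assay, not a number, and compound 1 sits at the same limit, as the note the limit of > 50000 nM in this assay, at which 2 of the 3 values shown sit, records. Only compound 2 returned a number. Within the data shown here, the one step that is readable, an at least 3.4-fold lower number from compound 1 to compound 2 (0.53 log units; beyond the scatter), comes from a bromo entering on an aromatic carbon; the reverse reading, an at least 3.4-fold higher number from compound 2 to compound 3 (0.53 log units; beyond the scatter), only repeats that compound 3 lies at the limit, while a step that the two limits leave unreadable from compound 1 to compound 3 cannot be read between two limits.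

Compound 4, `COc1ccc(C(=O)N(Cc2nc3ccccc3[nH]2)c2cc(OC)c(OC)c(OC)c2)cc1OC`, differs from compound 3 by 3,4-dimethoxyphenyl in place of 3-chlorophenyl on a carbonyl carbon. No measured step exchanges a halogen for methoxy groups, so nothing shown bears directly on this change, and the bromo result for compound 2 is the only hint that a substituted phenyl can give a number. Compound 4 is therefore expected to land somewhere between the limit and a weak number, with the estimated step of an at least 1.6-fold lower number from compound 3 to compound 4 (0.22 log units; that floor lies within the scatter). Compound 4 is estimated at 30000 nM, within 8000 nM to 50000 nM.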

Compound 4, half-maximal inhibitory concentration: 22400 nM
Compound 4: middle estimate off by 1.3-fold (0.13 log units), on the high side; the range from low to high includes it.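

With 3,4-dimethoxyphenyl on the carbonyl carbon, a second group gives a number in this assay, so a halogen is not needed for a reading at this position: the exchange for 3-chlorophenyl gives an at least 2.2-fold lower number from compound 3 to compound 4 (0.34 log units; beyond the scatter), and the exchange for phenyl gives an at least 2.2-fold lower number from compound 1 to compound 4 (0.34 log units; beyond the scatter). Set against 4-bromophenyl, the same group gives a 1.5-fold higher number from compound 2 to compound 4 (0.19 log units; within the scatter), so these two groups cannot be ranked here. The two steps that start from a limit are floors and not sizes: the limit of > 50000 nM in this assay, at which 2 of the 4 values shown sit.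

The compounds shown leave open why 4-bromophenyl and 3,4-dimethoxyphenyl give numbers while 3-chlorophenyl does not, and whether a single methoxy group would be enough. Also open, on these data alone, is how a phenyl ring carrying an amine or a carboxylic acid would read at this carbonyl carbon.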